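Working notes on the aryl swap from compound 1 to compound 3

The source may report more compounds than this note shows. Statements on the series, on what has been measured and on what is new or still open speak of the compounds shown alone.

Two compounds in this series carry readings in a physicochemical assay for permeability, using PAMPA; a lower number here means that the compound crosses the layer more slowly, a higher number that the compound crosses the layer faster. Compound 1 `Cc1oc(-c2ccc(Cl)cc2)nc1CN1CCC(C(=O)NCCCN2C[C@H](C)C[C@H](C)C2)CC1` sits at the upper edge of this assay, reported as > 635 10^-6 cm/s, which is a limit of the method and not a measured number. Compound 2 `Cc1ccccc1-c1nc(CN2CCC(C(=O)N3CCN(C4CCN(C)CC4)CC3)CC2)c(C)o1` sits at the opposite edge of this assay, reported as < 3.2 10^-6 cm/s, likewise a limit and not a number. The two readings are recorded as the limit of > 635 10^-6 cm/s in this assay, at which 1 of the 2 values shown sits, and (the limit of < 3.2 10^-6 cm/s in this assay, at which 1 of the 2 values shown sits). Within the data shown here, no pair of measured compounds differs in a single place, and compound 2 differs from compound 1 in several places at once, so its reading says nothing direct about the change considered here.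

Compound 3 `CCc1ccccc1-c1nc(CN2CCC(C(=O)NCCCN3C[C@H](C)C[C@H](C)C3)CC2)c(C)o1` is not yet measured. It differs from compound 1 in one place: 2-ethylphenyl in place of 4-chlorophenyl on an aromatic carbon.

With compound 1 already at the upper limit, the step from compound 1 to compound 3 is expected to be small or none beyond the scatter, so an at least 1.4-fold lower number from compound 1 to compound 3 (0.14 log units; that floor lies within the scatter) is expected. Compound 3 is expected to give about 450 10^-6 cm/s in this assay. For compound 3 the expected range runs from 120 10^-6 cm/s to 635 10^-6 cm/s, with a fair chance that only a limit is reported again.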

Compound 3, apparent permeability: 106 10^-6 cm/s
Beside the measured number, compound 3's estimate is 4.2-fold (0.63 log units) above it, and the stated range ends above it.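

In this assay, among these compounds, 2-ethylphenyl in place of 4-chlorophenyl on an aromatic carbon gives an at least 5.9-fold lower number from compound 1 to compound 3 (0.77 log units; beyond the scatter) and provides the first single-place step, showing that the reading responds to a change of aryl group at this position on the five-membered ring. As far as these compounds go, compound 1 stands at > 635 10^-6 cm/s as a limit of the method and not a number, so the step gives only a floor and its full size remains unknown. Compound 3, at 106 10^-6 cm/s as a measured number rather than a limit, gives the series a reference from which later steps at this position can be sized in either direction.

The single swap removes the chlorine and the 4-substituted pattern while adding the ethyl group and the 2-substituted pattern, so the compounds shown do not separate the identity of the substituent from its place on the phenyl ring. A 2-chlorophenyl or 4-ethylphenyl group on the same core would separate the two, and the compounds shown offer no measured property that accounts for the step.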